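The source may hold more compounds than are shown below. What is called first, only, known or untested is meant among the compounds shown, and "the series" means these compounds.

Measured compounds in a functional assay on MDA-MB-231 cells (Homo sapiens) for antiproliferative activity, read by MTT assay, with a stated time of 72 h; on this read-out higher numbers stand for weaker inhibition and lower numbers for stronger inhibition:
- compound 1 `O=C(Nc1ccc(-c2noc(-c3cccc(NS(=O)(=O)c4ccccc4)c3)n2)c(Cl)c1)c1cccnc1`: > 10000 nM
- compound 2 `Cc1ccc(S(=O)(=O)Nc2cccc(-c3nc(-c4ccc(NC(=O)c5cccnc5)cc4Cl)no3)c2)cc1`: > 10000 nM
- compound 3 `COc1cccc(S(=O)(=O)Nc2cccc(-c3nc(-c4ccc(NC(=O)c5cccnc5)cc4Cl)no3)c2)c1`: > 10000 nM

The value recorded for compound 3 is a limit of this assay, not a number. The value for compound 1 is likewise a limit. The value for compound 2 is a limit as well. All three shown values sit at the limit of > 10000 nM in this assay, at which 3 of the 3 values shown sit, so the three steps among them, a step that the two limits leave unreadable from compound 1 to compound 2, a step that the two limits leave unreadable from compound 1 to compound 3 and a step that the two limits leave unreadable from compound 2 to compound 3, have no readable size: a change of the aryl group on the sulfonyl sulfur has so far not moved any compound off the limit, in either direction.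

Compound 4 `CC(=O)Nc1ccc(S(=O)(=O)Nc2cccc(-c3nc(-c4ccc(NC(=O)c5cccnc5)cc4Cl)no3)c2)cc1` differs from compound 3 by 4-acetamidophenyl in place of 3-methoxyphenyl on a sulfonyl sulfur. The measured steps that bear on this change are the three above, each of unreadable size, so no step beyond the scatter can be expected in this assay from them; the most probable outcome for compound 4 is another limit.

On that basis compound 4 is estimated at 15000 nM, with a range from 5000 nM to 50000 nM. This estimate for compound 4 corresponds to an expected step that the limit leaves unreadable from compound 3 to compound 4.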

Compound 4, half-maximal inhibitory concentration: 2500 nM
Estimate against measurement, compound 4: 6.0-fold (0.78 log units) above; measured number outside the range, below it.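

In this assay, the aryl group on the sulfonyl sulfur is now shown to be a place where a change can move a compound off the limit: the change to 4-acetamidophenyl gives an at least 4.0-fold lower number from compound 3 to compound 4 (0.60 log units; beyond the scatter), while acetamido gives an at least 4.0-fold lower number from compound 2 to compound 4 (0.60 log units; beyond the scatter) and an at least 4.0-fold lower number from compound 1 to compound 4 (0.60 log units; beyond the scatter). Each of these sizes is only a minimum, and the steps among compound 1, compound 2 and compound 3 still cannot be read: the limit of > 10000 nM in this assay, at which 3 of the 4 values shown sit. Among the groups shown, a lower number goes with acetamido alone, since compound 2 with methyl and compound 3 with methoxy give no readable step.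

As far as these compounds go, it remains open whether the step depends on the amide hydrogen, the carbonyl or the whole 4-acetamidophenyl group. From the compounds shown here alone, a free amine or a longer acyl chain on that aryl ring also remains untested in these data.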